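Swapping the amide ring in a phosphodiesterase series

The source may report more compounds than this note shows. Statements on the series, on what has been measured and on what is new or still open speak of the compounds shown alone.

Measured so far in an assay on isolated protein for inhibition of phosphodiesterase 4A (Sus scrofa); on this read-out higher numbers stand for weaker inhibition and lower numbers for stronger inhibition:
Compound 1 `COc1ccc(C(=O)Nc2cccnc2)cc1OC1CCCC1` gives 550 nM.
Compound 2 `COc1ccc(C(=O)NC2(C)C=C(C)ON2)cc1OC1CCCC1` gives 450 nM.

Compound 2 and compound 1 sit within the scatter of each other: a 1.2-fold lower number from compound 1 to compound 2 (0.09 log units; within the scatter). Both share the same core, and they differ only in the ring carried on the amide-type nitrogen, so this position has so far tolerated a ring swap without a clear shift in this assay.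

Compound 3 `COc1ccc(C(=O)Nc2c(C)nsc2C#N)cc1OC1CCCC1` differs from compound 2 at the same place: a group of 8 heavy atoms (5 carbon, 2 nitrogen, 1 sulfur; one five-membered aromatic ring with 2 hetero atoms) in place of a group of 7 heavy atoms (5 carbon, 1 nitrogen, 1 oxygen; one five-membered non-aromatic ring with 2 hetero atoms), on an amide-type nitrogen. Within the data shown here, the only measured step that bears on this position is the one from compound 1 to compound 2, and it stayed within the scatter. Among the measured compounds shown here, with one such step as the sole guide, no shift beyond the scatter is expected in this assay for compound 3: the expected step is a 1.1-fold higher number from compound 2 to compound 3 (0.05 log units; within the scatter). Compound 3 is therefore estimated at 500 nM, with a range from 200 nM to 1500 nM that allows for the untested aromatic ring.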

Compound 3, half-maximal inhibitory concentration: 200 nM
Estimate against measurement, compound 3: 2.5-fold (0.40 log units) above; measured number inside the range.
By their numbers in this assay, from the lowest: compound 3; then compounds 2 and 1 (each within the scatter of the next).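

In this assay, the position on the amide-type nitrogen now proves sensitive to the group it carries: 5-cyano-3-methyl-1,2-thiazol-4-yl gives a stronger result than the earlier groups (a 2.3-fold lower number from compound 2 to compound 3 (0.35 log units; beyond the scatter); a 2.8-fold lower number from compound 1 to compound 3 (0.44 log units; beyond the scatter)). Among these compounds, both steps are modest, but they lie beyond the scatter, whereas the only earlier step at this position did not, so the choice of group here can change the number. No measurement available here explains this change.

Going by these compounds, it remains open which part of the new group matters most: the nitrile, the methyl or the five-membered aromatic ring itself. How the number would move with an amine or a carboxylic acid in place of the nitrile is also an open question.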